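Fluoro in place of nitro: compound 3 to compound 4

A few compounds are considered here, and "the series" means these few. Any claim that something is new, unique, unknown or untested is made for them only; others in the source may bear on it.

Of the compounds shown here, three sharing one core have been measured in a functional assay on CEM-SS cells (Homo sapiens) for cytotoxicity; on this read-out lower numbers stand for stronger inhibition and higher numbers for weaker inhibition. There, compound 1 (`COc1ccc(Cn2c(N)nc3cc(Cl)c(Cl)cc32)cc1`) gives 27000 nM, compound 2 (`Cc1ccc(Cn2c(N)nc3cc(Cl)c(Cl)cc32)cc1`) gives 40000 nM and compound 3 (`Nc1nc2cc(Cl)c(Cl)cc2n1Cc1ccc([N+](=O)[O-])cc1`) gives 32000 nM. For the measured compounds named here, compound 3 lies within the scatter of both others, so these three values set no order among the compounds.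

Compound 4 (`Nc1nc2cc(Cl)c(Cl)cc2n1Cc1ccc(F)cc1`) has not yet been measured. It carries fluoro in place of nitro on an aromatic carbon, para to a large group: fluoro in place of nitro on an aromatic carbon.

Going by the values given here, three measured steps bear on this change, each exchanging the group on that aromatic carbon. Methyl in place of methoxy gives a 1.5-fold higher number from compound 1 to compound 2 (0.17 log units; within the scatter). Nitro in place of methoxy gives a 1.2-fold higher number from compound 1 to compound 3 (0.07 log units; within the scatter). Nitro in place of methyl gives a 1.3-fold lower number from compound 2 to compound 3 (0.10 log units; within the scatter). Among the compounds with values here, none of the three moves the number beyond the scatter, although no measured compound carries fluoro, so this exchange itself is untested. No step beyond the scatter is therefore expected in this assay, and the expected step is a 1.0-fold higher number from compound 3 to compound 4 (0.01 log units; within the scatter). For compound 4 the estimated value is 33000 nM, with an expected range from 16000 nM to 65000 nM.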

Compound 4, half-maximal inhibitory concentration: 30000 nM
Estimate against measurement, compound 4: 1.1-fold (0.04 log units) above; low and high end bracket the measured number.
By their numbers in this assay, from the lowest: compounds 1, 4, 3 and 2 (each within the scatter of the next).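

In this assay, fluoro in place of nitro gives a 1.1-fold lower number from compound 3 to compound 4 (0.03 log units; within the scatter), fluoro in place of methyl gives a 1.3-fold lower number from compound 2 to compound 4 (0.12 log units; within the scatter) and fluoro in place of methoxy gives a 1.1-fold higher number from compound 1 to compound 4 (0.05 log units; within the scatter). Fluoro is the first halogen seen on this aromatic carbon, para to a large group, and the exchange for nitro also removes the hydrogen-bond acceptors of nitro and a double bond outside aromatic rings, yet all four compounds remain within the scatter of one another, so this wider set of groups still sets no order among them. No measurement on hand offers an explanation for this flat picture.

Whether any group on this carbon can move the number beyond the scatter stays open, since the compounds shown cover only methoxy, methyl, nitro and fluoro, and an amine, a carboxylic acid or a longer chain could behave differently. The compounds shown also leave open how much the rest of the shared core contributes, as each of them keeps the two chlorines and the free amine unchanged.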